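This account rests on a few compounds, and the source may have more. Where it says the series, first, only, none or still open, it means among the compounds named here.

Compound 1 `CCC(CC)Nc1nc(C)nc2c1nnn2-c1c(C)cc(C)cc1C`: 5.7 nM
Compound 2 `CCN(c1nc(C)nc2c1nnn2-c1ccc(C(C)C)cc1Br)C(COC)COC`: 123 nM

Both compounds were tested in an in vitro assay on 293-EBNA cells for binding affinity to corticotropin-releasing factor receptor 1 (Homo sapiens); a lower number here means a stronger inhibitor, a higher number a weaker inhibitor. Compound 2 gives the higher of the two numbers, and compound 1 gives a number lower by an amount beyond the usual scatter, so compound 2 is the weaker binder of this pair. Compound 3 `CCCCC(CCCC)Nc1nc(C)nc2c1nnn2-c1ccc(C(C)C)cc1Br` differs from compound 2 by a group of 10 heavy atoms (9 carbon, 1 nitrogen; no ring) in place of a group of 10 heavy atoms (7 carbon, 1 nitrogen, 2 oxygen; no ring), on an aromatic carbon. Compound 1 also bears a hydrogen on its chain nitrogen and gives 5.7 nM, so a downward step beyond the scatter is expected. Compound 3 is expected to give 15 nM, with a range from 4 nM to 60 nM. That estimate means a step of an 8.2-fold lower number from compound 2 to compound 3 (0.91 log units; beyond the scatter).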

Compound 3, inhibition constant: 4.5 nM
For compound 3 the middle estimate is 3.3-fold (0.52 log units) above the measured one; the measured number falls inside the stated range.
By their numbers in this assay, from the lowest: compounds 3 and 1 (each within the scatter of the next); then compound 2.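

At this aromatic carbon next to the ring nitrogen, the group matters greatly: in this assay the change gives a 27-fold lower number from compound 2 to compound 3 (1.44 log units; beyond the scatter). Groups of equal heavy-atom count, neither with a ring, therefore differ widely here, with the entering group carrying a hydrogen-bond donor and no oxygen. No supporting measurement explains the size of this step. From the compounds shown here alone, it remains open whether the hydrogen on the chain nitrogen or the loss of the two oxygens carries the step. Going by these compounds, a morpholine or a shorter dialkylamine at this position also remains untested by these compounds.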